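This account rests on a few compounds, and the source may have more. Where it says the series, first, only, none or still open, it means among the compounds named here.

Measured compounds and values in an ADME assay on Huh-5-2 cells (Homo sapiens) for cytotoxicity, read by WST assay, with a stated time of 3 days; on this read-out higher numbers stand for lower toxicity in this test and lower numbers for higher toxicity in this test:

Compound 1 `O=c1c(O)c(-c2ccccc2)oc2cc(OCc3ccccc3Cl)cc(O)c12`: > 100000 nM, a limit of this test.
Compound 2 `O=c1c(O)c(-c2ccccc2)oc2cc(OCc3ccccc3[N+](=O)[O-])cc(O)c12`: 32000 nM.
Compound 3 `O=c1c(O)c(-c2ccccc2)oc2cc(OCc3cccc(Br)c3)cc(O)c12`: > 100000 nM, a limit of this test.

Compound 3 stands at the ceiling of this assay, where the recorded value is a limit rather than a number; this is the limit of > 100000 nM in this assay, at which 2 of the 3 values shown sit, shared with compound 1. Compound 4 `Cc1cccc(COc2cc(O)c3c(=O)c(O)c(-c4ccccc4)oc3c2)c1` differs from compound 3 by methyl in place of bromo on an aromatic carbon.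

The measured steps do not touch this exchange directly. The step that the two limits leave unreadable from compound 1 to compound 3 is unreadable because both values are limits; the step of an at least 3.1-fold higher number from compound 2 to compound 3 (0.49 log units; beyond the scatter) shows that a substituent change at the same benzyl position can move the number, but that step involved the nitro group of compound 2, and an at least 3.1-fold lower number from compound 1 to compound 2 (0.49 log units; beyond the scatter) shows the nitro group as the one outlier among the three. For the measured compounds named here, no measured step bears on methyl against bromo.

The expectation for compound 4 in this assay is therefore no step beyond the scatter, a number no higher from compound 3 to compound 4 (the limit leaves the size open), with compound 4 most likely again reported as a limit. The estimate for compound 4 is 100000 nM, within 40000 nM to 250000 nM.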

Compound 4, half-maximal cytotoxic concentration: 35000 nM
For compound 4 the middle estimate is 2.9-fold (0.46 log units) above the measured one, outside the stated range (below it).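

Methyl in place of bromo gives an at least 2.8-fold lower number from compound 3 to compound 4 (0.45 log units; beyond the scatter), so in this assay an exchange of one heavy atom for one heavy atom, with no hydrogen-bond donor or acceptor on either side, is enough to move the number. The nitro compound no longer stands alone, with a 1.1-fold higher number from compound 2 to compound 4 (0.04 log units; within the scatter). The 3-methylbenzyl group also gives an at least 2.8-fold lower number from compound 1 to compound 4 (0.45 log units; beyond the scatter), and only the chloro and bromo compounds stay at a limit of the test: the limit of > 100000 nM in this assay, at which 2 of the 4 values shown sit.

Open, going by these compounds, is whether methyl and nitro would read alike at one and the same place on the ring, and likewise chloro and bromo. An amine or a carboxylic acid on the benzyl ring, or a longer chain in place of methyl, would show how far this change in the number extends.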